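This account rests on a few compounds, and the source may have more. Where it says the series, first, only, none or still open, it means among the compounds named here.

Measured so far in a functional assay on K562 cells (Homo sapiens) for inhibition, read by trypan blue exclusion, with a stated time of 72 h; a lower number here means a stronger inhibitor, a higher number a weaker inhibitor:
- compound 1 `Cn1c(=O)c(S(=O)(=O)c2ccc(C(=O)O)cc2)cc2cnc(Nc3ccc4[nH]ccc4c3)nc21` at 5000 nM
- compound 2 `Cn1c(=O)c(S(=O)(=O)Cc2ccc(F)cc2)cc2cnc(Nc3ccc4[nH]ccc4c3)nc21` at 30000 nM
- compound 3 `Cn1c(=O)c(S(=O)(=O)c2ccc(Cl)cc2)cc2cnc(Nc3ccc4[nH]ccc4c3)nc21` at 100 nM

Compound 3 has the lowest number of the three, and its gaps to the other two lie beyond the scatter. The next compound is compound 4 `Cn1c(=O)c(S(=O)(=O)c2ccc(Cl)cc2)cc2cnc(Nc3cnc4ccccc4c3)nc21` and the change from compound 3 is quinolin-3-yl in place of 1H-indol-5-yl on a nitrogen on an aromatic ring with the rest of the structure kept.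

Among the compounds with values here, no measured step touches this place. The modest 6.0-fold higher number from compound 1 to compound 2 (0.78 log units; beyond the scatter) and the large 50-fold lower number from compound 1 to compound 3 (1.70 log units; beyond the scatter) and the large 300-fold lower number from compound 2 to compound 3 (2.48 log units; beyond the scatter) all concern the group on the sulfonyl sulfur, so their sizes do not carry over directly. They show only that this series can move far on a single change. Compound 3 already stands lowest at 100 nM so a rise is expected to be more likely than a further fall, though without direct evidence.

The expected change is a 3.0-fold higher number from compound 3 to compound 4 (0.48 log units; beyond the scatter) and this is a modest rise with wide uncertainty. Compound 4 is estimated at 300 nM with an expected range from 50 nM to 2000 nM as the working figure.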

Compound 4, half-maximal inhibitory concentration: 15000 nM
Beside the measured number, compound 4's estimate is 50-fold (1.70 log units) below it; measured number outside the range, above it.
By their numbers in this assay, from the lowest: compound 3; then compound 1; then compounds 4 and 2 (each within the scatter of the next).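

In this assay, the group on the nitrogen on an aromatic ring matters greatly: a 150-fold higher number from compound 3 to compound 4 (2.18 log units; beyond the scatter) shows that the series is sensitive here as well as at the sulfonyl sulfur. The change replaces 1H-indol-5-yl (1 hydrogen-bond donor, 0 hydrogen-bond acceptors, a five-membered aromatic ring) with quinolin-3-yl (0 hydrogen-bond donors, 1 hydrogen-bond acceptor, two six-membered aromatic rings), so several counted features differ in this single step and it cannot separate their contributions. No measurement available here bears on the reason for this rise.

The compounds shown leave open whether a 1-methylindol-5-yl or a quinolin-6-yl group on this nitrogen would stay near compound 3 or near compound 4. They also leave open whether the order among sulfonyl groups would hold with quinolin-3-yl in place.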